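The source may report more compounds than this note shows. Statements on the series, on what has been measured and on what is new or still open speak of the compounds shown alone.

Three compounds share one core and differ only in the group attached to a nitrogen on an aromatic ring. Compound 1 `Clc1cccc(Nc2ncnc3ccc(NCc4ncc5ccccc5n4)cc23)c1` carries quinazolin-2-yl on a saturated chain carbon bound to that nitrogen, and in a functional assay on A549 cells (Homo sapiens) for antiproliferative activity, read by MTT assay, with a stated time of 48 h (a lower number here means a stronger inhibitor, a higher number a weaker inhibitor), compound 1 gives 1710 nM. Compound 2 `Clc1cccc(Nc2ncnc3ccc(NCc4c[nH]c5ccccc45)cc23)c1` carries 1H-indol-3-yl in the same way; in this assay compound 2 gives 2330 nM. Compound 3 `CSCCCNc1ccc2ncnc(Nc3cccc(Cl)c3)c2c1` carries a 3-(methylsulfanyl)propyl chain instead; in this assay compound 3 gives 3820 nM, the highest of the three numbers. Going by the values given here, the steps leading to it were a 2.2-fold higher number from compound 1 to compound 3 (0.35 log units; beyond the scatter) and a 1.6-fold higher number from compound 2 to compound 3 (0.21 log units; within the scatter), so only the step from the quinazolin-2-yl-bearing compound 1 lies beyond the scatter.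

Compound 4 `O=C(/C=C/c1cccs1)Nc1ccc2ncnc(Nc3cccc(Cl)c3)c2c1` takes the next step: (2-(thiophen-2-yl)ethenyl)carbonyl in place of 3-(methylsulfanyl)propyl on a nitrogen on an aromatic ring. Among the compounds with values here, no measured pair makes exactly this change, but both recorded steps go from a group holding an aromatic ring to a plain chain and give higher numbers, the larger one beyond the scatter. Going the other way, back to a group that holds an aromatic ring, is therefore expected to lower the number modestly, though the carbonyl link is new here and adds uncertainty. Because a 2.2-fold higher number from compound 1 to compound 3 (0.35 log units; beyond the scatter) is the nearest guide, the expected step is a 2.4-fold lower number from compound 3 to compound 4 (0.38 log units; beyond the scatter). Compound 4 is expected to give about 1600 nM in this assay, within a range from 500 nM to 5000 nM.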

Compound 4, half-maximal inhibitory concentration: 9310 nM
Estimate against measurement, compound 4: 5.8-fold (0.76 log units) below, outside the stated range (above it).
By their numbers in this assay, from the lowest: compounds 1, 2 and 3 (each within the scatter of the next, the first and the last beyond it); then compound 4.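

In this assay, putting (2-(thiophen-2-yl)ethenyl)carbonyl in place of 3-(methylsulfanyl)propyl on the nitrogen gives a 2.4-fold higher number from compound 3 to compound 4 (0.39 log units; beyond the scatter), a modest but real rise. This shows that holding an aromatic ring does not by itself give this position a lower number: compound 4 holds a five-membered aromatic ring, yet its number lies above those of compound 1 and compound 2, which also hold aromatic rings, and above that of the ringless compound 3. It is also the first compound shown with a carbonyl rather than a saturated chain carbon on this nitrogen, and nothing available explains why the number rises.

Compound 4 changes the ring, the double bond and the carbonyl link together, so the compounds shown leave open which of these goes with the higher number. A thiophen-2-ylmethyl group on the same nitrogen would keep the ring without the carbonyl, while a plain acetyl group would keep the carbonyl without the ring, and the result for either remains an open question.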